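Compound 2 to Compound 4: One Methoxy Group Instead of Three

A few compounds are considered here, and "the series" means these few. Any claim that something is new, unique, unknown or untested is made for them only; others in the source may bear on it.

Measured so far:
Compound 1 `COc1cc2ncnc(Nc3ccc(F)c(Cl)c3)c2cc1NC(=O)/C=C/c1ccc(C#N)cc1`: "not active" (no number reported)
Compound 2 `COc1ccc(/C=C/C(=O)Nc2cc3c(Nc4ccc(F)c(Cl)c4)ncnc3cc2O[C@H]2CCOC2)c(OC)c1OC`: 70 nM
Compound 3 `COc1cc2ncnc(Nc3ccc(F)c(Cl)c3)c2cc1NC(=O)/C=C/c1ccc(F)cc1Cl`: "not active" (no number reported)

For the measured compounds named here, in a functional assay on A549 cells (Homo sapiens) for cytotoxicity, read by MTT assay, with a stated time of 72 h (on this read-out higher numbers stand for weaker inhibition and lower numbers for stronger inhibition), compound 2 gives 70 nM, the only number reported. For compound 1 and compound 3 this assay reports no number; each is described only as inactive, so compound 2 cannot be placed in order against them beyond noting that it alone yields a measurable value.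

Compound 4 `COc1ccc(/C=C/C(=O)Nc2cc3c(Nc4ccc(F)c(Cl)c4)ncnc3cc2O[C@H]2CCOC2)cc1` keeps everything in compound 2 apart from one change: 4-methoxyphenyl in place of 2,3,4-trimethoxyphenyl on a double-bonded chain carbon bound to a double-bonded chain carbon. Compound 1 and compound 3 differ from compound 2 in more than one place, so they give no direct reading of what this single change does. Going by the values given here, no step between measured compounds exists here, and the expectation therefore rests on compound 2 alone. A move from a three-acceptor aryl group to a one-acceptor aryl group at the same place is expected to cost some potency, but not to abolish it, so a step from compound 2 to compound 4 of a 2.1-fold higher number from compound 2 to compound 4 (0.33 log units; beyond the scatter) is expected, somewhat beyond the scatter in the weaker direction. Compound 4 is estimated to give 150 nM in this assay, with a range from 40 nM to 600 nM.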

Compound 4, half-maximal inhibitory concentration: 3050 nM
For compound 4 the middle estimate is 20-fold (1.31 log units) below the measured one, and the stated range ends below it.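

The earlier compounds shown here offered a single number and no step, so they could not show whether the aryl group on a double-bonded chain carbon bound to a double-bonded chain carbon matters in this assay at all. Replacing 2,3,4-trimethoxyphenyl with 4-methoxyphenyl brings a 44-fold higher number from compound 2 to compound 4 (1.64 log units; beyond the scatter) as the result of this one change, so the methoxy substitution of this aryl group strongly affects the read-out, although compound 4 still gives a measured number. No measurement shown here explains why the loss is so large.

The two compounds differ only as a whole group. They do not reveal whether the loss follows from removing one particular methoxy group or from removing them together. Nor do they show whether a hydroxyl group or a dimethylamino group at this place on the ring would restore the value of compound 2, and compound 1 and compound 3, which differ from compound 2 in more than one place, cannot settle either question.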